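The source may report more compounds than this note shows. Statements on the series, on what has been measured and on what is new or still open speak of the compounds shown alone.

Among the measured compounds shown here, compound 1, with the structure `N#Cc1cnc(NCc2cnccc2C(F)(F)F)cc1NC[C@H]1C[C@H](O)C1`, sits in the middle of the three numbers measured so far. In an assay on isolated protein for inhibition of protein kinase C theta type (Homo sapiens), read by TR-FRET, with a stated time of 2 h (on this read-out higher numbers stand for weaker inhibition and lower numbers for stronger inhibition), compound 1 gives 700 nM. Compound 2, drawn as `N#Cc1cnc(NCc2ccccc2C(F)(F)F)cc1N[C@H]1CC[C@@H](O)CC1`, gives 140 nM in this assay, and its mirror image compound 3, drawn as `N#Cc1cnc(NCc2ccccc2C(F)(F)F)cc1N[C@H]1CC[C@H](O)CC1`, gives 4000 nM. For the measured compounds named here, the only measured step in which one thing changes is the one between these two: a 29-fold higher number from compound 2 to compound 3 (1.46 log units; beyond the scatter), and it rests on (the fact that compounds 2 and 3 differ only in the configuration as drawn), the fact that the two compounds are the same in every atom and bond and differ only in the configuration as drawn. Going by the values given here, compound 1 differs from both of them in two places at once, so no single step joins it to either.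

Compound 4, with the structure `CO[C@H]1CC[C@H](Nc2cc(NCc3cnccc3C(F)(F)F)ncc2C#N)CC1`, is the unmeasured compound. Its difference from compound 1 is 4-methoxycyclohexyl in place of (3-hydroxycyclobutyl)methyl on a nitrogen on an aromatic ring: a 4-methoxycyclohexyl group takes the place of the (3-hydroxycyclobutyl)methyl group, with the number of hydrogen-bond donors on that side falling from one to none. Among the compounds with values here, no measured step covers this exchange; the one step known, from compound 2 to compound 3, warns only that a change on this ring can move the number a long way in either direction. For compound 4 the step of a 2.1-fold higher number from compound 1 to compound 4 (0.33 log units; beyond the scatter) is therefore expected to be a modest worsening with a wide margin, and the estimate for compound 4 is 1500 nM, with a range from 300 nM to 8000 nM.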

Compound 4, half-maximal inhibitory concentration: 1100 nM
Estimate against measurement, compound 4: 1.4-fold (0.13 log units) above, within the range that was stated.
By their numbers in this assay, from the lowest: compound 2; then compounds 1 and 4 (each within the scatter of the next); then compound 3.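

In this assay, exchanging the group on a nitrogen on an aromatic ring gives a 1.6-fold higher number from compound 1 to compound 4 (0.20 log units; within the scatter). Among the compounds shown here, the earlier compounds showed only that configuration on a ring at this nitrogen can matter, whereas here a whole group is replaced: 4-methoxycyclohexyl has a six-membered ring in place of a four-membered one, more heavy atoms and no hydrogen-bond donor, and the number does not move beyond the scatter. For this one pair, then, losing the hydrogen-bond donor of the (3-hydroxycyclobutyl)methyl group does not come with a measurable loss, though nothing shown explains this outcome or tells whether the several differences act separately or offset one another.

Still open, on these data alone, is how the number would respond to an amine or a carboxylic acid in place of the methoxy group on the cyclohexyl ring, or to a longer chain carrying that ring on the nitrogen. Also open, as far as these compounds go, is whether the methoxy-bearing ring of compound 4 depends on configuration as strongly as the hydroxy-bearing ring does in a 29-fold higher number from compound 2 to compound 3 (1.46 log units; beyond the scatter).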